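Chloro-methylpyrimidine isomers: cytotoxicity notes on compounds 1 and 4

The source may hold more compounds than are shown below. What is called first, only, known or untested is meant among the compounds shown, and "the series" means these compounds.

Measured compounds:
- compound 1 `Cc1cc(Cl)nc(NCCCCCCNc2ccnc3cc(Cl)ccc23)n1`: 24000 nM
- compound 2 `Cc1cc(Cl)nc(NCCNc2ccnc3cc(Cl)ccc23)n1`: 42300 nM
- compound 3 `Cc1cc(NCCCCNc2ccnc3cc(Cl)ccc23)nc(N2CCN(C)CC2)n1`: 34600 nM

All three values come from an ADME assay on LLC-PK11 cells (Sus scrofa) for cytotoxicity, read by neutral red uptake, with a stated time of 48 h; on this read-out higher numbers stand for weaker inhibition and lower numbers for stronger inhibition. In this assay compound 1, at 24000 nM, lies within the scatter of both compound 2 and compound 3, so the numbers give these three compounds no order. No two of the measured compounds differ in only one place, so the series offers no direct measure of what a single change does.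

The next compound to be measured is compound 4 `Cc1cc(NCCCCCCNc2ccnc3cc(Cl)ccc23)nc(Cl)n1`. Its difference from compound 1 is 2-chloro-6-methylpyrimidin-4-yl in place of 4-chloro-6-methylpyrimidin-2-yl on an amine nitrogen. In words, 2-chloro-6-methylpyrimidin-4-yl stands in place of 4-chloro-6-methylpyrimidin-2-yl on an amine nitrogen, with the same atoms joined differently.

No step beyond the scatter is expected in this assay, and no direction can be favoured. The expectation rests on compound 1 at 24000 nM and on compound 3 at 34600 nM, which differ in more than one place and still stay within the scatter of each other. The estimate is a 1.1-fold higher number from compound 1 to compound 4 (0.05 log units; within the scatter), which is expected to stay within the scatter.

For compound 4 the expected value is 27000 nM, with an estimated range of 13000 nM to 55000 nM.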

Compound 4, half-maximal inhibitory concentration: 15800 nM
Compound 4: the middle estimate sits 1.7-fold (0.23 log units) above what was measured; low and high end bracket the measured number.
By their numbers in this assay, from the lowest: compounds 4, 1, 3 and 2 (each within the scatter of the next, the first and the last beyond it).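

In this assay the series now has its first comparison of compounds that differ in one place: 2-chloro-6-methylpyrimidin-4-yl in place of 4-chloro-6-methylpyrimidin-2-yl on an amine nitrogen gives a 1.5-fold lower number from compound 1 to compound 4 (0.18 log units; within the scatter) for this change. For the compounds shown here, at this position, then, two groups with the same atoms joined differently are not told apart by this read-out, something the earlier compounds could not show, as none of them differed from another in only one place. No measurement available here speaks to what lies behind this result.

Still open, on these data alone, is whether a carboxylic acid or a primary amine in place of the chlorine on 2-chloro-6-methylpyrimidin-4-yl would give a step beyond the scatter in this assay, a question that a swap between isomers cannot answer. Going by these compounds alone, also open is whether the two isomeric groups would read alike on a longer chain, since the only direct comparison of them so far rests on the single pair of compound 1 and compound 4.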